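Moving the Bromine Around the Aniline Ring

This account rests on a few compounds, and the source may have more. Where it says the series, first, only, none or still open, it means among the compounds named here.

Measured so far in a functional assay on COLO 205 cells (Homo sapiens) for cytotoxicity, read by MTT assay, with a stated time of 48 h; on this read-out higher numbers stand for weaker inhibition and lower numbers for stronger inhibition:
Compound 1 `COc1ccccc1Nc1nc(-c2cccc(F)c2)nc2ccc(F)cc12` gives > 50000 nM, which is a limit of the assay and not a number.
Compound 2 `Fc1cccc(-c2nc(Nc3cccc(Br)c3)c3cc(F)ccc3n2)c1` gives > 50000 nM, likewise a limit and not a number.

Compound 2 therefore stands at the upper edge of what this assay can report, where both values shown sit (the limit of > 50000 nM in this assay, at which 2 of the 2 values shown sit). Compound 3 `Fc1cccc(-c2nc(Nc3ccccc3Br)c3cc(F)ccc3n2)c1` differs from compound 2 by 2-bromophenyl in place of 3-bromophenyl on a nitrogen on an aromatic ring. Among the measured compounds shown here, the only measured step, a step that the two limits leave unreadable from compound 1 to compound 2, runs between two limits and cannot be sized, so it offers no readable guide for this new change. Lacking any readable step, compound 3 is expected to remain near the limit, with a number no higher from compound 2 to compound 3 (the limit leaves the size open) as the expected step. The estimate for compound 3 is 50000 nM, spanning 15000 nM to 150000 nM.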

Compound 3, half-maximal inhibitory concentration: > 50000 nM
Compound 3: only a limit was reported; the forecaster's own chance of this, stated with the estimate: 80%; the middle value sits exactly at the limit.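

Compound 1, compound 2 and compound 3 all stop at the same reporting limit, so no step among them can be read: the limit of > 50000 nM in this assay, at which 3 of the 3 values shown sit.

The compounds shown leave open whether 2-bromophenyl, 3-bromophenyl and 2-methoxyphenyl differ at all in strength.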